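The compounds below may be only part of what the source reports. "The series", "measured", "known", "first", "only" and "open" are said of these compounds alone.

Measured so far in an ADME assay on PANC-1 cells (Homo sapiens) for cytotoxicity, read by MTT assay; on this read-out higher numbers stand for lower toxicity in this test and lower numbers for higher toxicity in this test:
Compound 1 `Cc1nc(-c2cccnc2)sc1-c1nnc(-c2cccnc2)o1` gives > 100 ug/mL in this assay, a limit of the assay rather than a number.
Compound 2 `Cc1ccccc1-c1nnc(-c2sc(-c3cccnc3)nc2C)o1` gives > 100 ug/mL, again a limit.
Compound 3 `Cc1cccc(-c2nnc(-c3sc(-c4cccnc4)nc3C)o2)c1` gives > 100 ug/mL, again a limit.

Compound 1 therefore stands only at a limit; all three values sit at the limit of > 100 ug/mL in this assay, at which 3 of the 3 values shown sit, so no ordering among them can be read. Compound 4 `Cc1nc(-c2cccnc2)sc1-c1nnc(-c2ccc(O)cc2)o1` has not yet been measured; its change from compound 1 is 4-hydroxyphenyl in place of pyridin-3-yl on an aromatic carbon. Going by the values given here, the steps that bear on this position, a step that the two limits leave unreadable from compound 1 to compound 2 and a step that the two limits leave unreadable from compound 1 to compound 3, carry no readable size, and a step that the two limits leave unreadable from compound 2 to compound 3 adds nothing further. No direction beyond the scatter can be set from these data. The step from compound 1 to compound 4 is expected to be a step that the limit leaves unreadable from compound 1 to compound 4. Compound 4 is estimated at 150 ug/mL, within 60 ug/mL to 400 ug/mL, most likely reported again as a limit.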

Compound 4, half-maximal cytotoxic concentration: > 100 ug/mL
Compound 4: no number, only a limit; the forecaster's own chance of this, stated with the estimate: 85%; the middle value does not contradict the limit.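

Compound 4 is again a limit, so its steps from compound 1, compound 2 and compound 3 cannot be read: the limit of > 100 ug/mL in this assay, at which 4 of the 4 values shown sit.
The compounds shown leave open whether any group on the shared core gives a measurable half-maximal cytotoxic concentration.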